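Adding One Chloro to the Strongest of Three

The source may report more compounds than this note shows. Statements on the series, on what has been measured and on what is new or still open speak of the compounds shown alone.

In a functional assay on T47D cells (Homo sapiens) for cytotoxicity, read by MTT assay, with a stated time of 3 h (a lower number here means a stronger inhibitor, a higher number a weaker inhibitor), three compounds have been measured so far. Compound 1 `O=C(CN1CCN(c2cc(=O)[nH]c3ccc(F)cc23)CC1)Nc1nc(-c2ccccc2)cs1` gives 7200 nM, the lowest of the three numbers and therefore the strongest result in this small set. Compound 3 `Cc1ccc(-c2csc(NC(=O)CN3CCN(c4cc(=O)n(-c5ccccc5)c5ccccc45)CC3)n2)cc1` gives 16500 nM. Compound 2 `O=c1cc(N2CCNCC2)c2cc(F)ccc2[nH]1` gives 37700 nM. Both of these numbers lie above that of compound 1 by more than the usual scatter of repeated measurements, and compound 2 lies furthest away.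

Compound 4 `O=C(CN1CCN(c2cc(=O)[nH]c3ccc(F)cc23)CC1)Nc1nc(-c2ccc(Cl)cc2)cs1` has not yet been measured. It differs from compound 1 in a single place: chloro in place of hydrogen on an aromatic carbon. The phenyl group of compound 1 thus becomes a 4-chlorophenyl group in compound 4.

Among the measured compounds shown here, no two measured compounds differ in only one place, so the data offer no direct guide to the effect of this change. The expectation therefore starts from compound 1 at 7200 nM, and it stays cautious. In this assay, I expect no step beyond the scatter, with a slight lean towards a lower number. The estimated step runs a 1.2-fold lower number from compound 1 to compound 4 (0.08 log units; within the scatter). For compound 4, the expected value is 6000 nM, with an estimated range from 2500 nM to 14000 nM.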

Compound 4, half-maximal inhibitory concentration: 2730 nM
For compound 4 the middle estimate is 2.2-fold (0.34 log units) above the measured one; the range from low to high includes it.
By their numbers in this assay, from the lowest: compound 4; then compound 1; then compound 3; then compound 2.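

In this assay, replacing the phenyl group of the shared structure with a 4-chlorophenyl group gives a 2.6-fold lower number from compound 1 to compound 4 (0.42 log units; beyond the scatter). Among the compounds shown here, this is the first comparison in the set in which only one place changes, and it shows that this aromatic carbon, para to a large group, is not indifferent to what it carries: adding a single chlorine atom, with no new ring and no net charge, moves the number by more than the usual scatter, though the step is modest. Nothing measured here explains this shift, so the result records a change in the number and not its cause.

The compounds shown leave open whether the step is specific to chloro or would also appear with another group on the same carbon, such as bromo, methoxy, an amine or a carboxylic acid. For the compounds shown here, they also leave open whether the same exchange would give a similar step on a different core, since this one pair is the only direct comparison available.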